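A few compounds are considered here, and "the series" means these few. Any claim that something is new, unique, unknown or untested is made for them only; others in the source may bear on it.

Three compounds have been measured:
compound 1 `CCN(Cc1cccs1)C(=O)c1cc2cc(C)ccc2[nH]1`, 2010 nM;
compound 2 `Cc1ccc(OCC(=O)N(Cc2cccs2)c2ccccn2)cc1`, 200 nM;
compound 3 `CCN(Cc1ccccc1)C(=O)COc1ccc(C)cc1`, 1880 nM.

These numbers come from an assay on HEK293 cells for agonist activity at transient receptor potential cation channel subfamily M member 8 (Homo sapiens), read by fluorescence and calcium flux, with a stated time of 15 min; on this read-out lower numbers stand for an effect already at smaller amounts and higher numbers for an effect only at larger amounts of compound. Compound 2 stands at the lowest of the three numbers, and its gaps to compound 3 and to compound 1 both lie beyond the usual scatter of repeated measurements. Compound 4 `Cc1ccc(OCC(=O)N(CCCO)Cc2cccs2)cc1` has not yet been measured. It differs from compound 2 in one place: 3-hydroxypropyl in place of pyridin-2-yl on an amide-type nitrogen. Among the measured compounds shown here, no measured pair differing in only one place exists, so the change has no direct precedent. The nearest guide is compound 3, which carries no ring on its amide-type nitrogen and gives 1880 nM. A higher number, beyond the scatter, is therefore expected, a 7.5-fold higher number from compound 2 to compound 4 (0.88 log units; beyond the scatter). Compound 4 is estimated at 1500 nM, within a range from 400 nM to 6000 nM.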

Compound 4, half-maximal effective concentration: 3000 nM
The estimate for compound 4 lay 2.0-fold (0.30 log units) below the measured number; low and high end bracket the measured number.
By their numbers in this assay, from the lowest: compound 2; then compounds 3, 1 and 4 (each within the scatter of the next).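

In this assay, putting 3-hydroxypropyl in place of pyridin-2-yl on the amide-type nitrogen gives a 15-fold higher number from compound 2 to compound 4 (1.18 log units; beyond the scatter), the first direct comparison showing that this position is sensitive to what it carries. The change removes a six-membered aromatic ring and adds a hydrogen-bond donor, and this single pair cannot separate those two differences. Nothing available explains the rise. Still open, as far as these compounds go, is what a phenyl ring or a plain propyl chain would give on this nitrogen. These two groups could help separate the roles of the ring, its nitrogen and the hydroxyl.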